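The compounds below may be only part of what the source reports. "The series", "measured", "known", "first", "only" and "open" are said of these compounds alone.

Working notes on the series, read in a functional assay for inhibition, with Homo sapiens as the target; a higher number here means a weaker inhibitor, a lower number a stronger inhibitor. The compounds share one core and differ in the group on a saturated ring carbon. Compound 1 `Cc1cc2c(cc1C(=O)N=C(N)N)S(=O)(=O)CC2C(C)C`, with isopropyl, gives 77 nM. Compound 2 `Cc1cc2c(cc1C(=O)N=C(N)N)S(=O)(=O)CC2C`, with methyl, gives 182 nM. Compound 3 `Cc1cc2c(cc1C(=O)N=C(N)N)S(=O)(=O)CC2O`, with hydroxy, gives 1050 nM, the highest number of the three and so the weakest inhibitor among them.

The next step leads to compound 4 `Cc1cc2c(cc1C(=O)N=C(N)N)S(=O)(=O)CC2`, with hydrogen in place of hydroxy on a saturated ring carbon.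

Within the data shown here, no compound with hydrogen at this place has been measured, so the evidence is indirect. The hydroxy group was the costly one, as shown by a 5.8-fold higher number from compound 2 to compound 3 (0.76 log units; beyond the scatter) and by a 14-fold higher number from compound 1 to compound 3 (1.13 log units; beyond the scatter). Removing it should therefore recover part of that loss. Recovery is unlikely to be complete, since the change among the carbon groups, a 2.4-fold higher number from compound 1 to compound 2 (0.37 log units; beyond the scatter), suggests that less carbon at this place goes with a higher number. Compound 4 is thus expected to sit near or somewhat above compound 2 at 182 nM, and clearly below compound 3.

The expected change is a modest one towards a stronger inhibitor: a 3.0-fold lower number from compound 3 to compound 4 (0.48 log units; beyond the scatter). For compound 4 the estimated value is 350 nM, with an expected range of 130 nM to 900 nM.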

Compound 4, half-maximal inhibitory concentration: 587 nM
Compound 4: middle estimate off by 1.7-fold (0.22 log units), on the low side; the measured number falls inside the stated range.
By their numbers in this assay, from the lowest: compound 1; then compound 2; then compounds 4 and 3 (each within the scatter of the next).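

In this assay, the replacement of hydroxy by hydrogen on this saturated ring carbon gives a step that does not clear the usual scatter (a 1.8-fold lower number from compound 3 to compound 4 (0.25 log units; within the scatter)), so hydrogen and hydroxy cannot be told apart at this place. The gap to the carbon groups remains (a 3.2-fold higher number from compound 2 to compound 4 (0.51 log units; beyond the scatter)) and widens with isopropyl (a 7.6-fold higher number from compound 1 to compound 4 (0.88 log units; beyond the scatter)), so the higher number seen earlier with hydroxy is not specific to hydroxy: it also appears with hydrogen, and the two carbon groups are what give the lower numbers in this set. Among compounds 1, 2 and 4 the number rises stepwise from isopropyl through methyl to hydrogen, a trend that now rests on three points, while compound 3 carries no carbon at this place and stands outside that sequence.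

Nothing at hand accounts for this order at the position. The compounds shown leave open whether a longer chain such as n-butyl, or a cyclohexyl ring, extends the trend past isopropyl, and whether an amine or a methoxy group at this place reads like hydroxy and hydrogen.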